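Removing a Chlorine from a Sulfonamide Antagonist

The source may report more compounds than this note shows. Statements on the series, on what has been measured and on what is new or still open speak of the compounds shown alone.

Compound 1, `CCCCC(CC)C(=O)Nc1ccc2ccn(Cc3ccc(C(=O)NS(=O)(=O)c4ccc(Cl)cc4)cc3OC)c2c1`: 7.8
Compound 2, `COC(=O)C(C(=O)c1ccc(Cn2ncc3ccc(NC(=O)OC4CCCC4)cc32)c(OC)c1)S(=O)(=O)c1ccccc1`: 9.9

Within the data shown here, in a functional assay (trachea) for antagonist activity, with Cavia porcellus as the target (on this read-out lower numbers stand for lower potency and higher numbers for higher potency (the scale is a negative logarithm)), compound 1 gives 7.8, the lower of the two numbers measured so far. Compound 2 gives 9.9 in this assay, and the gap between these two values is beyond the usual scatter; the two structures differ in many places at once, so no single change can be read from that gap. Compound 3, `CCCCC(CC)C(=O)Nc1ccc2ccn(Cc3ccc(C(=O)NS(=O)(=O)c4ccccc4)cc3OC)c2c1`, is not yet measured. It differs from compound 1 in one place: hydrogen in place of chloro on an aromatic carbon. Among the measured compounds shown here, no measured pair shows this change on its own, so its effect cannot be read from the data at hand. For compound 3 a small loss, or no change beyond the scatter, is expected, the step being a number 0.20 log units lower from compound 1 to compound 3 (within the scatter). Compound 3 is estimated at 7.6, between 7 and 8.2.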

Compound 3, negative logarithm of the antagonist equilibrium constant: 8.6
For compound 3 the middle estimate is 1.00 log units below the measured one; measured number outside the range, above it.
By their numbers in this assay, from the lowest: compound 1; then compound 3; then compound 2.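

In this assay, replacing 4-chlorophenyl with phenyl gives a number 0.80 log units higher from compound 1 to compound 3 (beyond the scatter). Among these compounds, this is the first measured step that isolates a single change, and it shows that a chloro at this place on the ring is not needed for potency; on the core of compound 1, the version with hydrogen there is the more potent of the two. No measurement at hand bears on the reason for this step.

On these data alone, whether fluoro, a nitrile or an amine at the same place would give a higher or lower number than hydrogen remains open. This single pair also leaves open whether swapping chloro for hydrogen would give a similar step on a different core.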